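Acetyl substitution on the pyrrole core of the carbamate series

The source may report more compounds than this note shows. Statements on the series, on what has been measured and on what is new or still open speak of the compounds shown alone.

Three carbamates have been measured in an assay on microsomes from brain (strain Sprague-Dawley) for inhibition of Fatty-acid amide hydrolase 1 (Rattus norvegicus), read by fluorescence and HPLC, with stated times of 10 min and 60 min; a higher number here means a weaker inhibitor, a lower number a stronger inhibitor. Compound 1 `Cc1c(C#N)c(-c2ccccc2)c(-c2ccccc2)n1CCCCCCNC(=O)Oc1ccccc1` gives 8700 nM; compound 2 `O=C(NCCCCCCCCn1ccc2ccccc21)Oc1ccccc1` gives 240 nM; compound 3 `Cc1cc(-c2ccccc2)c(-c2ccccc2)n1CCCCCCNC(=O)Oc1ccccc1` gives 2600 nM. Compound 3 thus stands second highest of the three numbers, nearer to compound 1 than to compound 2. Among the compounds with values here, the one single-point step measured so far, a 3.3-fold lower number from compound 1 to compound 3 (0.52 log units; beyond the scatter), shows that removing a cyano group from this aromatic carbon helps. Compound 4 `CC(=O)c1c(-c2ccccc2)c(-c2ccccc2)n(CCCCCCNC(=O)Oc2ccccc2)c1C` reverses that direction: acetyl in place of hydrogen on an aromatic carbon. An acetyl group, carrying a carbonyl, occupies the same carbon that cyano did in compound 1, so a weaker number is expected in this assay, of a size comparable to the cyano step, a 2.9-fold higher number from compound 3 to compound 4 (0.46 log units; beyond the scatter). For compound 4 the expected value in this assay is 7500 nM, with a range of 2500 nM to 22000 nM.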

Compound 4, half-maximal inhibitory concentration: > 10000 nM
Compound 4: no number, only a limit; the forecaster's own chance of this, stated with the estimate: 15%; middle value at least 1.3-fold (0.12 log units) from the limit.
By their numbers in this assay, from the lowest: compound 2; then compound 3; then compound 1. At a limit, above all of these: compound 4.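

In this assay, compound 4 gives a limit, not a number: the limit of > 10000 nM in this assay, at which 1 of the 4 values shown sits. Acetyl in place of hydrogen on this aromatic carbon gives an at least 3.8-fold higher number from compound 3 to compound 4 (0.58 log units; beyond the scatter), so both substituents shown here, cyano and acetyl, give weaker inhibition than hydrogen. Acetyl in place of cyano gives an at least 1.1-fold higher number from compound 1 to compound 4 (0.06 log units; that floor lies within the scatter), which does not order the two groups.

As far as these compounds go, the true size of the acetyl loss remains unknown beyond the limit. Also open, from the compounds shown here alone, is whether an amine, a carboxylic acid or a methyl on this carbon would match or improve on hydrogen.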